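This account rests on a few compounds, and the source may have more. Where it says the series, first, only, none or still open, it means among the compounds named here.

Measured compounds
Compound 1, `COc1ccc(Cn2cc(/C=N\NC(=O)c3c[nH]c4ccccc34)c3cc(OC)ccc32)cc1`: in a functional assay on LNCaP cells (Homo sapiens) for cytotoxicity (on this read-out higher numbers stand for weaker inhibition and lower numbers for stronger inhibition), compound 1 gives only a limit, > 100000 nM.
Compound 2, `COc1ccc2c(c1)c(/C=N\NC(=O)c1cn(C)c3ccccc13)cn2Cc1ccc(Cl)cc1`: in this assay compound 2 likewise gives only a limit, > 100000 nM.
Compound 3, `O=C(N/N=C\c1cn(Cc2ccc(Cl)cc2)c2cc(F)ccc12)c1c[nH]c2ccccc12`: in this assay compound 3 gives 55200 nM.

Within the data shown here, compound 3 therefore holds the only real number in the set; the other two values sit at the limit of > 100000 nM in this assay, at which 2 of the 3 values shown sit, so no measured step between any two compounds can be stated, and where compound 3 stands relative to compound 1 or compound 2 is not known beyond the fact that it returned a number where they did not.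

Among the measured compounds shown here, compound 4, `Cn1cc(C(=O)N/N=C\c2cn(Cc3ccc(Cl)cc3)c3cc(F)ccc23)c2ccccc21`, is the one unmeasured compound. It differs from compound 3 in a single place: methyl in place of hydrogen on an aromatic nitrogen. Compound 2 carries the same methylated nitrogen and compound 1 the unmethylated one, but both sit at the limit, so these two values show nothing about the size of such a step.

For the measured compounds named here, with no measured step to lean on, the expectation for compound 4 rests on compound 3 alone: the step of a 1.4-fold higher number from compound 3 to compound 4 (0.16 log units; within the scatter) is expected to be small, not clearly beyond the usual scatter, leaning if anything towards weaker inhibition. Compound 4 is accordingly estimated at 80000 nM, with a likely range from 30000 nM to 200000 nM.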

Compound 4, half-maximal inhibitory concentration: > 100000 nM
Compound 4 gave a limit, no number (the forecaster's own chance of this, stated with the estimate: 40%); middle value at least 1.2-fold (0.09 log units) away from the limit.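

Methyl in place of hydrogen on an aromatic nitrogen, which turns 1H-indol-3-yl into 1-methyl-1H-indol-3-yl, now has its first readable step in this assay: an at least 1.8-fold higher number from compound 3 to compound 4 (0.25 log units; that floor lies within the scatter). Compound 1 and compound 2 could not provide such a step, but this one gives only a floor, so the real difference may be large or may not exceed the usual scatter, and a real loss of inhibition on methylation is not established. The position therefore yields a direction that is left open rather than a size, and compound 3 remains the only compound with a real number, in a set that otherwise rests on a single ceiling: the limit of > 100000 nM in this assay, at which 3 of the 4 values shown sit.

The compounds shown leave open how much of the inhibition seen with compound 3 depends on the hydrogen on this nitrogen, since a value for compound 4 beyond the limit is unavailable. They also leave open how this nitrogen would respond to an ethyl group, an acetyl group or a longer chain ending in an amine or a carboxylic acid.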